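This account rests on a few compounds, and the source may have more. Where it says the series, first, only, none or still open, it means among the compounds named here.

In a functional assay on HeLa cells (Homo sapiens) for antiproliferative activity, read by MTT assay, with a stated time of 72 h (on this read-out higher numbers stand for weaker inhibition and lower numbers for stronger inhibition), compound 3, `COc1ccc2oc(CSC(=S)N3CCOCC3)cc(=O)c2c1`, gives only a limit, > 25000 nM, and not a number. Compound 1, `CCOC(=O)c1cc(=O)c2cc(CSC(=S)N(C(C)C)C(C)C)ccc2o1`, likewise gives only a limit in this assay, > 25000 nM. Compound 2, `O=c1c(SC(=S)N2CCCC2)coc2ccc(Cl)cc12`, gives a number in this assay, 16300 nM. Compound 3 therefore stands at the weak end of what is shown, together with compound 1, since (the limit of > 25000 nM in this assay, at which 2 of the 3 values shown sit). Compound 4, `COc1ccc2oc(CSC(=S)N(C(C)C)C(C)C)cc(=O)c2c1`, differs from compound 3 in one place: diisopropylamino in place of morpholin-4-yl on a thiocarbonyl carbon. For the measured compounds named here, no pair of measured compounds differs in just this way, so the step has no direct precedent, and compound 1 carries the same diisopropylamino group on another core while sitting at the limit. The estimated step from compound 3 to compound 4 is a step that the limit leaves unreadable from compound 3 to compound 4, no change beyond the scatter. Compound 4 is expected to give about 30000 nM, within 8000 nM to 100000 nM.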

Compound 4, half-maximal inhibitory concentration: > 25000 nM
Compound 4: a limit, no number; the forecaster's own chance of this, stated with the estimate: 65%; the middle value does not contradict the limit.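

Compound 3 and compound 4 both give only a limit and not a number, so no step between them can be read: the limit of > 25000 nM in this assay, at which 3 of the 4 values shown sit.

As far as these compounds go, whether diisopropylamino and morpholin-4-yl differ at all on this shared core remains open.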